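Swapping the Aryl Group on the Amine Nitrogen

The source may hold more compounds than are shown below. What is called first, only, known or untested is meant among the compounds shown, and "the series" means these compounds.

Compound 2 `O=C1C(Nc2ccc(C(F)(F)F)cc2)=CC(=O)c2c1nc1n2[C@H]2OC[C@@H](O)[C@H]2OC1` stands lowest of the two numbers in a functional assay on ECa-109 cells for inhibition, with ECa-109 cell line (Homo sapiens) as the target, read by sulforhodamine B assay (on this read-out lower numbers stand for stronger inhibition and higher numbers for weaker inhibition), with 2250 nM; its nearest neighbour is compound 1 `O=C1C(Nc2ccccc2F)=CC(=O)c2c1nc1n2[C@H]2OC[C@@H](O)[C@H]2OC1`, which gives 2660 nM, and the step of a 1.2-fold lower number from compound 1 to compound 2 (0.07 log units; within the scatter) lies within the scatter. Compound 3 `O=C1C=C(N2CCCCC2)C(=O)c2c1nc1n2[C@H]2OC[C@@H](O)[C@H]2OC1` reaches only a limit in this assay, > 8000 nM. Compound 4 `O=C1C(Nc2cccc(F)c2)=CC(=O)c2c1nc1n2[C@H]2OC[C@@H](O)[C@H]2OC1` differs from compound 2 in one place: 3-fluorophenyl in place of 4-(trifluoromethyl)phenyl on an amine nitrogen. Going by the values given here, the single measured step that bears on such a change of the group on the amine nitrogen is the one from compound 1 to compound 2, which did not exceed the scatter; compound 3 adds only (the limit of > 8000 nM in this assay, at which 1 of the 3 values shown sits). The account therefore expects no step beyond the scatter, a 1.1-fold higher number from compound 2 to compound 4 (0.05 log units; within the scatter). Compound 4 is estimated at 2500 nM, between 1200 nM and 5500 nM.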

Compound 4, half-maximal inhibitory concentration: 2370 nM
The estimate for compound 4 lay 1.1-fold (0.02 log units) above the measured number, within the range that was stated.
By their numbers in this assay, from the lowest: compounds 2, 4 and 1 (each within the scatter of the next). At a limit, above all of these: compound 3.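

In this assay, the 3-fluorophenyl group gives a 1.1-fold higher number from compound 2 to compound 4 (0.02 log units; within the scatter) and a 1.1-fold lower number from compound 1 to compound 4 (0.05 log units; within the scatter). On the amine nitrogen, 2-fluorophenyl, 3-fluorophenyl and 4-(trifluoromethyl)phenyl thus read alike, so the fluorine can sit at either of two printed places on the phenyl ring, or give way to trifluoromethyl, with every step staying within the scatter. Compound 3 remains a limit, not a number: the limit of > 8000 nM in this assay, at which 1 of the 4 values shown sits.

As far as these compounds go, what stays open is whether a phenyl ring carrying an amine or a carboxylic acid would break this flat picture. From the compounds shown here alone, a benzyl group on the same nitrogen is equally open.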